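Isopropyl to 4-methoxycyclohexyl on an aromatic nitrogen

This account rests on a few compounds, and the source may have more. Where it says the series, first, only, none or still open, it means among the compounds named here.

In an in vitro ADME assay on microsomes (Homo sapiens) for metabolic stability (a higher number here means that the compound lasts longer, a lower number that the compound disappears faster), compound 1 (`CNC(=O)Nc1ccc(-c2nc(N3CC4CCC(C3)O4)c3cnn(C(C)C)c3n2)cc1`) gives 0.2 h, within the scatter of compound 2 (`O=C(Nc1ccccc1)Nc1ccc(-c2nc(N3CC4CCC(C3)O4)c3cnn(C4CCC5(CC4)OCCO5)c3n2)cc1`) at 0.217 h and compound 3 (`O=C(Nc1ccc(-c2nc(N3CC4CCC(C3)O4)c3cnn(C4CCC5(CC4)OCCO5)c3n2)cc1)Nc1cccnc1`) at 0.217 h. Compound 4 (`CNC(=O)Nc1ccc(-c2nc(N3CC4CCC(C3)O4)c3cnn([C@H]4CC[C@H](OC)CC4)c3n2)cc1`) differs from compound 1 in one place: 4-methoxycyclohexyl in place of isopropyl on an aromatic nitrogen. Among the compounds with values here, the only measured step, no change at the digits printed from compound 2 to compound 3 (within the scatter), lies elsewhere in the structure, and no measured step isolates this change. Compound 1 at 0.2 h and compound 2 at 0.217 h carry different groups on that nitrogen, so no step beyond the scatter is expected in this assay, in either direction. The estimated step is a 1.1-fold higher number from compound 1 to compound 4 (0.04 log units; within the scatter). The expected value for compound 4 is 0.22 h, with an estimated range from 0.1 h to 0.5 h.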

Compound 4, half-life: 0.25 h
Compound 4: middle estimate off by 1.1-fold (0.06 log units), on the low side; the measured number falls inside the stated range.
By their numbers in this assay, from the lowest: compounds 1, 2, 3 and 4 (each within the scatter of the next).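

Within the data shown here, on the aromatic nitrogen, 4-methoxycyclohexyl in place of isopropyl gives a 1.3-fold higher number from compound 1 to compound 4 (0.10 log units; within the scatter) in this assay, the first direct reading of a change at this position. Even with one six-membered carbon ring and one hydrogen-bond acceptor entering, the half-life stays within the scatter for this pair. No measurement available here offers an explanation for this result.

On these data alone, whether an amine or a carboxylic acid on the cyclohexyl ring would move the half-life beyond the scatter remains open. So does whether the opposite stereochemistry of the 4-methoxycyclohexyl group would read the same.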